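The source may hold more compounds than are shown below. What is called first, only, known or untested is meant among the compounds shown, and "the series" means these compounds.

Compounds measured:
Compound 1 `COc1ccc2c(=O)c(/C=C/C(=O)Nc3cc(C)ccc3C)coc2c1`, which in a functional assay (QGY7701 cells, Homo sapiens) for inhibition, read by MTT assay, with a stated time of 48 h (on this read-out lower numbers stand for stronger inhibition and higher numbers for weaker inhibition), gives only the limit > 100000 nM.
Compound 2 `COc1ccc2c(=O)c(/C=C/C(=O)Nc3ccccc3)coc2c1`, which gives 14000 nM.
Compound 3 `CCOc1ccc(NC(=O)/C=C/c2coc3cc(OC)ccc3c2=O)cc1`, which gives only the limit > 100000 nM.

Compound 1 therefore stands at the limit of the assay, not at a number, and the limit of > 100000 nM in this assay, at which 2 of the 3 values shown sit, shows it is not alone there. Compound 4 `COc1ccc2c(=O)c(/C=C/C(=O)Nc3ccc(F)cc3)coc2c1` differs from compound 1 in one place: 4-fluorophenyl in place of 2,5-dimethylphenyl on an amide-type nitrogen. The measured step that bears on this is an at least 7.1-fold lower number from compound 1 to compound 2 (0.85 log units; beyond the scatter), which also removes the 2,5-dimethylphenyl for a phenyl-type ring. The step of an at least 7.1-fold higher number from compound 2 to compound 3 (0.85 log units; beyond the scatter), with ethoxy in place of hydrogen on an aromatic carbon, warns that an added group on that ring can return the number to the limit; fluorine is smaller, so the expected step is an at least 4.0-fold lower number from compound 1 to compound 4 (0.60 log units; beyond the scatter). Compound 4 is estimated at 25000 nM, with a range from 8000 nM to 100000 nM.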

Compound 4, half-maximal inhibitory concentration: > 100000 nM
Compound 4: only a limit was reported (the forecaster's own chance of this, stated with the estimate: 35%); middle value at least 4.0-fold (0.60 log units) away from the limit.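

In this assay, adding a fluorine to the phenyl ring brings an at least 7.1-fold higher number from compound 2 to compound 4 (0.85 log units; beyond the scatter). The loss is therefore not confined to ethoxy, and among the compounds shown, only compound 2, with its plain phenyl on the amide-type nitrogen, gives a number rather than a limit: the limit of > 100000 nM in this assay, at which 3 of the 4 values shown sit.
The steps among compound 1, compound 3 and compound 4 join limits and cannot be read.

The compounds shown leave open whether an amine, a hydroxyl or a carboxylic acid on that phenyl ring would keep a number. They also leave open whether a benzyl group in place of the phenyl would do so.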